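A ring swap on the shared core

The source may hold more compounds than are shown below. What is called first, only, known or untested is meant among the compounds shown, and "the series" means these compounds.

compound 1 `CC(C)(C)c1nc(-c2cccs2)c2c(N)c(C#N)c(N)nc2n1`: 56000 nM
compound 2 `CC(C)(C)c1nc(-c2ccccn2)c2c(N)c(C#N)c(N)nc2n1`: 87000 nM

Within the data shown here, in a physicochemical assay for solubility, in phosphate buffer, with a stated time of 18 h (a higher number here means a more soluble compound, a lower number a less soluble compound), compound 2 gives 87000 nM, which lies within the scatter of the only other measured compound. The next compound, compound 3 `CC(C)(C)c1nc(-c2ncn[nH]2)c2c(N)c(C#N)c(N)nc2n1`, puts 1H-1,2,4-triazol-5-yl in place of pyridin-2-yl on an aromatic carbon. Among the measured compounds shown here, the one measured step at this place is a 1.6-fold higher number from compound 1 to compound 2 (0.19 log units; within the scatter). For the measured compounds named here, no measured compound carries the entering group, so this step is only a weak guide. The expected change is a 1.2-fold lower number from compound 2 to compound 3 (0.09 log units; within the scatter), with no shift beyond the scatter expected in either direction. For compound 3 the estimated value is 70000 nM, with an expected range from 25000 nM to 180000 nM.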

Compound 3, solubility: 64500 nM
For compound 3 the middle estimate is 1.1-fold (0.04 log units) above the measured one; low and high end bracket the measured number.
By their numbers in this assay, from the lowest: compounds 1, 3 and 2 (each within the scatter of the next).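

In this assay, moving to 1H-1,2,4-triazol-5-yl, with 1 hydrogen-bond donor where pyridin-2-yl has 0, gives a 1.3-fold lower number from compound 2 to compound 3 (0.13 log units; within the scatter), and the swap from thiophen-2-yl gives a 1.2-fold higher number from compound 1 to compound 3 (0.06 log units; within the scatter). All three aromatic rings at this position therefore lie within the scatter of one another, even with this change in ring size and hydrogen-bond donors from pyridin-2-yl. Nothing available explains these numbers. Still open, on these data alone, is whether a non-aromatic group here, such as an amine, a carboxylic acid or a longer chain, would move the number beyond the scatter.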